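Fluoro for Chloro in Three Methanesulfonamido Benzamides

The compounds below may be only part of what the source reports. "The series", "measured", "known", "first", "only" and "open" are said of these compounds alone.

Compound 1 `CS(=O)(=O)Nc1ccc(NC(=O)c2ccc(C#N)cc2)cc1Cl`: > 250000 nM
Compound 2 `CS(=O)(=O)Nc1ccc(NC(=O)c2cccc(C(F)(F)F)c2)cc1Cl`: > 250000 nM
Compound 3 `CS(=O)(=O)Nc1ccc(NC(=O)c2ccc(C#N)cc2)cc1F`: > 250000 nM

In an ADME assay on RAW264.7 cells (Mus musculus) for cytotoxicity, read by MTT assay, with a stated time of 48 h (a lower number here means a stronger inhibitor, a higher number a weaker inhibitor), compound 1 gives only a limit, > 250000 nM. Compound 3 likewise gives only a limit, > 250000 nM. Compound 2 also gives only a limit, > 250000 nM. The change from compound 1 to compound 3 is fluoro in place of chloro on an aromatic carbon, and its step that the two limits leave unreadable from compound 1 to compound 3 is not readable from two limits. How the cores of compound 1 and compound 2 differ is not broken down here. Compound 4 `CS(=O)(=O)Nc1ccc(NC(=O)c2cccc(C(F)(F)F)c2)cc1F` is not yet measured; it arises from compound 2 by the same change, (fluoro in place of chloro on an aromatic carbon). The step from compound 2 to compound 4 in this assay is expected to be a step that the limit leaves unreadable from compound 2 to compound 4, resting on (the limit of > 250000 nM in this assay, at which 3 of the 3 values shown sit). Compound 4 is expected to give 300000 nM, estimated between 150000 nM and 1000000 nM.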

Compound 4, half-maximal inhibitory concentration: 32300 nM
For compound 4 the middle estimate is 9.3-fold (0.97 log units) above the measured one; measured number outside the range, below it.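

In this assay, fluoro in place of chloro on the core of compound 2 gives an at least 7.7-fold lower number from compound 2 to compound 4 (0.88 log units; beyond the scatter), so on this core the change has a visible result. The same change from compound 1 to compound 3 cannot be read, so the data do not show whether the result carries from one core to the other. The size of the step on compound 2 is also only a bound, because compound 2 gives a limit rather than a number: the limit of > 250000 nM in this assay, at which 3 of the 4 values shown sit.

The compounds shown leave open whether the lower number of compound 4 depends on its trifluoromethyl group. They also leave open how fluoro in place of chloro would behave on a core carrying an amine or a carboxylic acid instead of trifluoromethyl or nitrile.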